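Anticonvulsant Screening of Succinimide Piperazine Amides

The source may hold more compounds than are shown below. What is called first, only, known or untested is meant among the compounds shown, and "the series" means these compounds.

Measured compounds:
Compound 1 `CCC(C(=O)N1CCN(c2ccccc2Cl)CC1)N1C(=O)CCC1=O` gives 0% in a functional assay on the whole organism (strain Swiss) with Mus musculus as the target, in the maximal electroshock model, with a stated time of 2 h, at a dose of 300 mg/kg by the intraperitoneal route; a higher number here means a stronger effect of the compound at the dose given, a lower number a weaker effect.
Compound 2 `CCC(C(=O)N1CCN(c2cccc(F)c2)CC1)N1C(=O)CCC1=O` gives 0% in this assay.
Compound 3 `CC(C(=O)N1CCN(c2cccc(F)c2)CC1)N1C(=O)CCC1=O` gives 100% in this assay.

Compound 3 stands highest of the three, with both steps toward it beyond the scatter. The two cores differ by hydrogen in place of methyl on a saturated chain carbon, two bonds along the chain from an amide-type nitrogen in a ring and a carbonyl carbon, and this step, a number 100 percentage points higher from compound 2 to compound 3 (beyond the scatter), is the one large effect seen. Compound 4 `CC(C(=O)N1CCN(c2ccccc2Cl)CC1)N1C(=O)CCC1=O` is not yet measured; it differs from compound 3 by 2-chlorophenyl in place of 3-fluorophenyl on an amine nitrogen in a ring. The same change, (2-chlorophenyl in place of 3-fluorophenyl on an amine nitrogen in a ring), has been measured once, as no change at the digits printed from compound 2 to compound 1 (within the scatter). That earlier step, though, runs between two compounds that both give nothing, so it cannot show whether the aryl group matters when the rest of the molecule is active. For compound 4 the expected step is a number 25 percentage points lower from compound 3 to compound 4 (beyond the scatter), a modest fall from compound 3 with wide uncertainty, resting on the flat step no change at the digits printed from compound 2 to compound 1 (within the scatter) and on the large gain a number 100 percentage points higher from compound 2 to compound 3 (beyond the scatter) that compound 4 shares with compound 3. Compound 4 is therefore estimated at 75%, between 25% and 100%.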

Compound 4, a percentage reported as activity, at one dose (the size of the read-out at that dose, not a potency): 0%
For compound 4 the middle estimate is 75 percentage points above the measured one; measured number outside the range, below it.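

In this assay, putting 2-chlorophenyl in place of 3-fluorophenyl gives a number 100 percentage points lower from compound 3 to compound 4 (beyond the scatter), yet the same swap on the other core changed nothing, so this change does not carry a single effect from one core to another: the same change on two cores in this assay, no change at the digits printed (within the scatter) from compound 2 to compound 1 and a number 100 percentage points lower (beyond the scatter) from compound 3 to compound 4, 100 percentage points apart, beyond the scatter of two such steps The chain change behaves the same way, with hydrogen in place of methyl giving no change at the digits printed from compound 1 to compound 4 (within the scatter), a sharp contrast with its large gain when 3-fluorophenyl is present: the same change on two cores in this assay, a number 100 percentage points higher (beyond the scatter) from compound 2 to compound 3 and no change at the digits printed (within the scatter) from compound 1 to compound 4, 100 percentage points apart, beyond the scatter of two such steps Among these four compounds, activity appears only in compound 3, where hydrogen and 3-fluorophenyl occur together, but this does not show why the two changes depend on each other, and a single dose cannot reveal differences among compounds that give no effect.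

The swap alters both the halogen and where it sits, so the compounds shown do not separate these two features. On these data alone, it also remains open whether a plain phenyl group on the amine nitrogen, or a longer chain in place of the methyl, would keep or lose the effect.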